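A few compounds are considered here, and "the series" means these few. Any claim that something is new, unique, unknown or untested is made for them only; others in the source may bear on it.

Working notes on the series.

Compound 1 `ClCc1ccc(Cn2cnc3c(Cl)ncnc32)cc1` gives 72400 nM in a functional assay on PC-3 cells (Homo sapiens) for cytotoxicity, read by sulforhodamine B assay, with a stated time of 48 h; a lower number here means a stronger inhibitor of growth, a higher number a weaker inhibitor of growth. Compound 2 `Nc1nc(Cl)c2ncn(Cc3ccc(CCl)cc3)c2n1` gives 25100 nM in this assay, and the change amino in place of hydrogen on an aromatic carbon moved the number by a 2.9-fold lower number from compound 1 to compound 2 (0.46 log units; beyond the scatter). Compound 3 `ClCc1ccccc1Cn1cnc2c(Cl)ncnc21` gives 10500 nM in this assay; how the core of compound 3 differs from the core of compound 1 is not broken down here, beyond the two holding the same atoms joined differently.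

Compound 4 `Nc1nc(Cl)c2ncn(Cc3ccccc3CCl)c2n1` is not yet measured in this assay. It differs from compound 3 by amino in place of hydrogen on an aromatic carbon, which is the same change as that from compound 1 to compound 2, at the same place. Because the earlier step was a 2.9-fold lower number from compound 1 to compound 2 (0.46 log units; beyond the scatter), a comparable step is expected, a 2.6-fold lower number from compound 3 to compound 4 (0.42 log units; beyond the scatter). Compound 4 is therefore estimated at 4000 nM, within 1500 nM to 10000 nM.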

Compound 4, concentration for total growth inhibition: 67600 nM
Beside the measured number, compound 4's estimate is 17-fold (1.23 log units) below it; the measured number lies above the stated range.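

Amino in place of hydrogen on an aromatic carbon gives a 6.4-fold higher number from compound 3 to compound 4 (0.81 log units; beyond the scatter) in this assay and so does not carry over from the core of compound 1 to the core of compound 3 in either size or direction, as the two steps set side by side show: the same change on two cores in this assay, a 2.9-fold lower number (0.46 log units; beyond the scatter) from compound 1 to compound 2 and a 6.4-fold higher number (0.81 log units; beyond the scatter) from compound 3 to compound 4, 19-fold (1.27 log units) apart, beyond the scatter of two such steps
Going by these compounds alone, the step seen on one of these cores is therefore no guide to the step on the other. Two pairs do not show why the steps part, nor how the change would behave on any further core.

Still open, as far as these compounds go, is whether another group on the same aromatic carbon, such as methylamino or hydroxyl, would follow the step to compound 2 or the step to compound 4. From the compounds shown here alone, whether a further core would side with either step also remains open.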